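Extending the azole on the amide arm of compound 2

The source may hold more compounds than are shown below. What is called first, only, known or untested is meant among the compounds shown, and "the series" means these compounds.

Compound 1 `Cc1nc(C)n(CC(=O)N2CCN(c3sc(C(F)(F)F)nc3-c3nc4c(F)cccc4[nH]3)C[C@H]2C)n1`: 321 nM
Compound 2 `C[C@@H]1CN(c2sc(C(F)(F)F)nc2-c2nc3ccccc3[nH]2)CCN1C(=O)Cn1cccn1`: 191 nM
Compound 3 `Cc1nc(C)n(CC(=O)N2CCN(c3sc(C(F)(F)F)nc3-c3nc4ccc(C(C)(C)O)c(F)c4[nH]3)C[C@H]2C)n1`: 628 nM

These three compounds, which share one core, have been measured in a functional assay on Venous blood for antagonist activity at C-X-C chemokine receptor type 3 (Homo sapiens), read by flow cytometry, with a stated time of 30 min, in the presence of a further agent that is not named here; on this read-out higher numbers stand for weaker inhibition and lower numbers for stronger inhibition. Compound 2 has the lowest number of the three. Its gap to compound 1 lies within the usual scatter of such measurements, so no order between those two can be claimed; its gap to compound 3 lies beyond the scatter. The step from compound 2 to compound 4 `C[C@@H]1CN(c2sc(C(F)(F)F)nc2-c2nc3ccccc3[nH]2)CCN1C(=O)Cn1cnc2cccnc21` alters only the group on the amide arm: a group of 9 heavy atoms (6 carbon, 3 nitrogen; one five-membered aromatic ring with 2 hetero atoms, one six-membered aromatic ring with 1 hetero atom) in place of a group of 5 heavy atoms (3 carbon, 2 nitrogen; one five-membered aromatic ring with 2 hetero atoms), on a saturated chain carbon bound to a carbonyl carbon. Among the compounds with values here, no measured pair in this set differs in just this way, so there is no matched step to lean on, and the three numbers above give no guidance on how this read-out responds to a larger group at this place. The estimate therefore keeps compound 4 close to compound 2, with the move expected to stay within the scatter, in no clear direction. Compound 4 is expected to give about 170 nM, with a range from 60 nM to 500 nM. The step that this estimate means, a 1.1-fold lower number from compound 2 to compound 4 (0.05 log units; within the scatter), is expected to fall within the scatter.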

Compound 4, half-maximal inhibitory concentration: 70 nM
Compound 4: the middle estimate sits 2.4-fold (0.39 log units) above what was measured; the measured number falls inside the stated range.
By their numbers in this assay, from the lowest: compound 4; then compounds 2, 1 and 3 (each within the scatter of the next, the first and the last beyond it).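

In this assay, the place on a saturated chain carbon bound to a carbonyl carbon accepts a larger group without loss: replacing 1H-pyrazol-1-yl with the group of 9 heavy atoms gives a 2.7-fold lower number from compound 2 to compound 4 (0.44 log units; beyond the scatter), a modest step. The entering group retains a five-membered aromatic ring with 2 hetero atoms and adds a six-membered aromatic ring with 1 hetero atom, so this read-out is shown to respond to the size and make-up of the azole group at this place, which compound 1 and compound 3 could not show, as each differs from compound 2 in more than one place. No measurement at hand accounts for the step.

Within the data shown here, the single pair does not separate the effect of the added six-membered ring from that of its ring nitrogen, and a benzimidazol-1-yl group, which has an all-carbon benzene ring there, would draw that distinction. On these data alone, whether the same change would carry over to the shared core with a fluorine or a 2-hydroxypropan-2-yl group on it also remains open.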